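Methyl in place of cyano: compound 3 to compound 4

The source may hold more compounds than are shown below. What is called first, only, known or untested is meant among the compounds shown, and "the series" means these compounds.

Three compounds were measured in an ADME assay on microsomes from liver (Homo sapiens) for metabolic stability; on this read-out higher numbers stand for fast clearance and lower numbers for slow clearance.
Compound 1 `CCC(Oc1ccc(-n2cc(C(F)(F)F)cn2)cc1)c1ccc(C(=O)NCCC(=O)O)cc1` gives < 8 mL/min/kg, a limit of the assay, not a number.
Compound 2 `O=C(O)CCNC(=O)c1ccc(C(Oc2ccc(-n3cc(C(F)(F)F)cn3)cc2)C2CCCC2)cc1` gives 22 mL/min/kg.
Compound 3 `CCCC(Oc1ccc(-n2cc(C#N)cn2)cc1)c1ccc(C(=O)NCCC(=O)O)cc1` gives < 8 mL/min/kg, again a limit rather than a number.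

Compound 3 therefore sits at the low edge of what this assay can report, a position it shares with compound 1, as the limit of < 8 mL/min/kg in this assay, at which 2 of the 3 values shown sit, records. Compound 4 `CCCC(Oc1ccc(-n2cc(C)cn2)cc1)c1ccc(C(=O)NCCC(=O)O)cc1` differs from compound 3 by methyl in place of cyano on an aromatic carbon. For the measured compounds named here, the single measured step, an at least 2.7-fold higher number from compound 1 to compound 2 (0.43 log units; beyond the scatter), concerns a different place in the molecule and so does not bear on this change. Going by the values given here, with no measured step speaking to methyl in place of cyano, compound 4 is expected to stay near the limit, with an estimated step of a number no lower from compound 3 to compound 4 (the limit leaves the size open). Compound 4 is thus estimated at 8 mL/min/kg, between 4 mL/min/kg and 16 mL/min/kg.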

Compound 4, clearance: 16 mL/min/kg
For compound 4 the middle estimate is 2.0-fold (0.30 log units) below the measured one, within the range that was stated.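

For the compounds shown here, with the switch from 4-cyano-1H-pyrazol-1-yl to 4-methyl-1H-pyrazol-1-yl, this position on the five-membered aromatic ring is the first place outside the saturated chain carbon to be read in this assay, giving an at least 2.0-fold higher number from compound 3 to compound 4 (0.30 log units; that floor lies within the scatter). Going by these compounds, compound 4 gives a number rather than a limit, yet the true size of the step stays unknown. The limit still stands in the series: the limit of < 8 mL/min/kg in this assay, at which 2 of the 4 values shown sit.

What the compounds shown leave open is how an amine or a methoxy group would read at this position. Also open, on these data alone, is whether the step holds on a cyclopentyl compound.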